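Thiosemicarbazones on HL-60 cells: cyano to methoxy

This account rests on a few compounds, and the source may have more. Where it says the series, first, only, none or still open, it means among the compounds named here.

compound 1 (`CN(C)C(=S)N/N=C/c1cc2cccnc2s1`): > 100000 nM in a functional assay on HL-60 cells (Homo sapiens) for antiproliferative activity, read by sulforhodamine B assay, with a stated time of 72 h (a lower number here means a stronger inhibitor, a higher number a weaker inhibitor), a limit of the assay
compound 2 (`N#Cc1ccc(NC(=S)N/N=C/c2ccc3ccccc3n2)cc1`): 4660 nM in this assay
compound 3 (`NC(=S)N/N=C/c1nc2ccccc2s1`): > 100000 nM in this assay, a limit of the assay

Among the compounds with values here, compound 2 stands alone among the measured values: it is the only one reported as a number, while the other two sit at the limit of > 100000 nM in this assay, at which 2 of the 3 values shown sit. Within the data shown here, no two measured compounds differ in a single place, so no measured step can be quoted, and the cores of compound 1 and compound 3 are not those of compound 2.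

Compound 4 (`COc1ccc(NC(=S)N/N=C/c2ccc3ccccc3n2)cc1`) differs from compound 2 by methoxy in place of cyano on an aromatic carbon. Among the measured compounds shown here, nothing among the measured compounds speaks to this exchange, so no direction is given by the data. The step of a 1.7-fold higher number from compound 2 to compound 4 (0.23 log units; within the scatter) is expected to be modest, at the edge of the scatter or a little weaker. Compound 4 is therefore estimated to give about 8000 nM in this assay, with a range from 2000 nM to 40000 nM.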

Compound 4, half-maximal inhibitory concentration: 43800 nM
The estimate for compound 4 lay 5.5-fold (0.74 log units) below the measured number; the measured number lies above the stated range.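

Methoxy in place of cyano on the aromatic carbon para to a large group gives a 9.4-fold higher number from compound 2 to compound 4 (0.97 log units; beyond the scatter) in this assay, the first readable step in the series and evidence that the activity of the shared core depends on the group at this position. The two groups have the same counts of heavy atoms and hydrogen-bond acceptors, so those counts alone do not set the number. Nothing measured here explains the size of the step.

As far as these compounds go, with one step, no trend across substituents can be drawn, and it remains open where an amine or a carboxylic acid at this position would fall relative to compound 2 and compound 4. Compound 1 and compound 3 have other cores and stand at limits of the assay, so steps from them to compound 2 or compound 4 cannot be read.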